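The compounds below may be only part of what the source reports. "The series", "measured", "known", "first", "only" and "open" are said of these compounds alone.

Measured so far in a physicochemical assay for solubility, at pH 7.4; on this read-out lower numbers stand for lower solubility and higher numbers for higher solubility:
compound 1 `Cc1ccc(-c2c[nH]cn2)cc1NC(=O)c1ccc(OCc2ccccn2)cc1`: 90000 nM
compound 2 `Cc1cc(C)c(-c2cn(C)cn2)cc1NC(=O)c1ccc(OCc2ccccn2)cc1`: 8000 nM
compound 3 `Cc1csc(-c2cc(NC(=O)c3ccc(OCc4ccccn4)cc3)c(C)cc2C)n1`: < 1000 nM

Compound 1 `Cc1ccc(-c2c[nH]cn2)cc1NC(=O)c1ccc(OCc2ccccn2)cc1` gives 90000 nM in this assay, and compound 2 `Cc1cc(C)c(-c2cn(C)cn2)cc1NC(=O)c1ccc(OCc2ccccn2)cc1` gives 8000 nM. For compound 3 `Cc1csc(-c2cc(NC(=O)c3ccc(OCc4ccccn4)cc3)c(C)cc2C)n1` this assay reports only a limit, < 1000 nM. Compound 3 therefore sits at the limit of < 1000 nM in this assay, at which 1 of the 3 values shown sits, and no number is known for it. For the measured compounds named here, the one measured step that exchanges the heteroaryl ring, an at least 8.0-fold lower number from compound 2 to compound 3 (0.90 log units; beyond the scatter), runs downward to that limit.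

Compound 4 `Cc1cc(C)c(-c2c(C)nn(C)c2C)cc1NC(=O)c1ccc(OCc2ccccn2)cc1` is not yet measured. It differs from compound 3 in the same region: 1,3,5-trimethyl-1H-pyrazol-4-yl in place of 4-methyl-1,3-thiazol-2-yl on an aromatic carbon. Going by the values given here, no measured step covers this exact exchange; the step from compound 2 to compound 3 is the only related one, and it shows that swapping one five-membered aromatic ring for another can move this assay by at least a modest amount. For compound 4, the expected step is an at least 1.5-fold higher number from compound 3 to compound 4 (0.17 log units; that floor lies within the scatter), with little support from the measured numbers. Compound 4 is estimated at 1500 nM in this assay, between 500 nM and 6000 nM.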

Compound 4, solubility: 35000 nM
For compound 4 the middle estimate is 23-fold (1.37 log units) below the measured one; measured number outside the range, above it.
By their numbers in this assay, from the lowest: compound 2; then compound 4; then compound 1. At a limit, below all of these: compound 3.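

Compound 3 stands at a limit in this assay, the only such value among the compounds shown: the limit of < 1000 nM in this assay, at which 1 of the 4 values shown sits. Even so, exchanging one five-membered aromatic ring for another at this position can raise the number as well as lower it, as the change to 1,3,5-trimethyl-1H-pyrazol-4-yl gives an at least 35-fold higher number from compound 3 to compound 4 (1.54 log units; beyond the scatter). The same group also outdoes 1-methyl-1H-imidazol-4-yl, with a 4.4-fold higher number from compound 2 to compound 4 (0.64 log units; beyond the scatter), and since 4-methyl-1,3-thiazol-2-yl and 1,3,5-trimethyl-1H-pyrazol-4-yl carry equal counts of ring hetero atoms, donors and acceptors, those counts do not settle the read-out here.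

Going by these compounds, the true value of compound 3 remains unknown, so the full size of its step cannot be read. Also open, on these data alone, are which of the three methyl groups on the new ring matter, and what an amine or a carboxylic acid on that ring would give.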